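The source may hold more compounds than are shown below. What is called first, only, known or untested is meant among the compounds shown, and "the series" means these compounds.

Measured so far in a functional assay on OVCAR-3 cells (Homo sapiens) for inhibition, read by colorimetric assay and sulforhodamine B assay, with a stated time of 48 h; on this read-out lower numbers stand for stronger inhibition of growth and higher numbers for weaker inhibition of growth:
compound 1 `CCCCCCCCCCCC[C@@H](O)[C@H]1CC[C@H]([C@H](O)CCCCCCCCCCNC(=O)c2cccs2)O1`: 42.7 nM
compound 2 `CCCCCCCCCCCC[C@@H](O)[C@H]1CC[C@H]([C@H](O)CCCCCCCCCCNC(=O)c2ccco2)O1`: 100000 nM
compound 3 `CCCCCCCCCCCC[C@@H](O)[C@H]1CC[C@H]([C@H](O)CCCCCCCCCCNC(=O)c2ccoc2)O1`: 100000 nM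

Compound 3 stands level with compound 2, and both sit at the weak end, far from compound 1. The unmeasured compound 4 `CCCCCCCCCCCC[C@@H](O)[C@H]1CC[C@H]([C@H](O)CCCCCCCCCCNC(=O)c2cncs2)O1` keeps the shared core and alters only the ring on the carbonyl carbon: 1,3-thiazol-5-yl in place of furan-3-yl on a carbonyl carbon. The entering 1,3-thiazol-5-yl holds sulfur, as the thiophen-2-yl of compound 1 does. Among the measured compounds shown here, two steps bear on this: a 2300-fold higher number from compound 1 to compound 2 (3.37 log units; beyond the scatter), and a 2300-fold higher number from compound 1 to compound 3 (3.37 log units; beyond the scatter). Exchanging one furan for the other gave no change at the digits printed from compound 2 to compound 3 (within the scatter). A large move toward stronger inhibition in this assay is therefore expected, though with much uncertainty, and the expected change is a 200-fold lower number from compound 3 to compound 4 (2.30 log units; beyond the scatter). For compound 4 the estimated value is 500 nM, with an expected range of 20 nM to 100000 nM.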

Compound 4, concentration for 50% growth inhibition: 100000 nM
Compound 4: the middle estimate sits 200-fold (2.30 log units) below what was measured, within the range that was stated.
By their numbers in this assay, from the lowest: compound 1; then compounds 2, 3 and 4 (each within the scatter of the next).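

In this assay, having sulfur in the ring does not by itself bring back the strength of compound 1: 1,3-thiazol-5-yl holds sulfur too, yet the result is a 2300-fold higher number from compound 1 to compound 4 (3.37 log units; beyond the scatter). This ring instead matches both furans, with no change at the digits printed from compound 3 to compound 4 (within the scatter) and no change at the digits printed from compound 2 to compound 4 (within the scatter), so on this carbonyl carbon thiophen-2-yl alone stands apart among the four rings. Nothing available here explains this difference. Still open, going by these compounds, is whether thiophen-3-yl or a plain phenyl ring in the same place would behave like thiophen-2-yl or like the other three rings.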